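Aryl amide in place of pentyl on the shared core

This account rests on a few compounds, and the source may have more. Where it says the series, first, only, none or still open, it means among the compounds named here.

Within the data shown here, compound 3 `C=CC1=C(C(=O)NCCCCC)C(c2ccc(OC)cc2)OC1` gives the only outright number in a functional assay on A549 cells (Homo sapiens) for cytotoxicity, read by MTT assay, with a stated time of 24 h (a higher number here means a weaker inhibitor, a lower number a stronger inhibitor), namely 36500 nM. Compound 1 `C=CC1=C(C(=O)NC(C)(C)C)C(c2ccc(OC)cc2)OC1` reaches only a limit in this assay, > 100000 nM. Compound 2 `C=CC1=C(C(=O)NCc2ccc(Cl)cc2)C(c2ccc(OC)cc2)OC1` likewise gives a limit in this assay, > 100000 nM. Compound 4 `C=CC1=C(C(=O)Nc2ccccc2OC)C(c2ccc(OC)cc2)OC1` differs from compound 3 by 2-methoxyphenyl in place of pentyl on an amide-type nitrogen. Among the measured compounds shown here, two measured steps bear on this change: an at least 2.7-fold lower number from compound 1 to compound 3 (0.43 log units; beyond the scatter) and an at least 2.7-fold lower number from compound 2 to compound 3 (0.43 log units; beyond the scatter), both running towards the pentyl amide, while compound 4 runs the other way, from pentyl to an aromatic ring, so a higher number in this assay is expected for compound 4, of the size a 2.5-fold higher number from compound 3 to compound 4 (0.39 log units; beyond the scatter), with a real chance of ending at the limit of > 100000 nM in this assay, at which 2 of the 3 values shown sit. Compound 4 is therefore estimated at 90000 nM, within a range from 30000 nM to 300000 nM.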

Compound 4, half-maximal inhibitory concentration: > 100000 nM
Compound 4: a limit, no number; the forecaster's own chance of this, stated with the estimate: 55%; middle value at least 1.1-fold (0.04 log units) away from the limit.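

The change from pentyl to 2-methoxyphenyl on the amide-type nitrogen gives an at least 2.7-fold higher number from compound 3 to compound 4 (0.43 log units; beyond the scatter) in this assay. The earlier compounds had shown this only for tert-butyl and 4-chlorobenzyl; an aromatic ring carried directly on this nitrogen now joins them, leaving compound 3 as the only amide with an outright number: the limit of > 100000 nM in this assay, at which 3 of the 4 values shown sit. The steps from compound 1 and from compound 2 to compound 4 join two limits and cannot be read.

Left open is whether a longer chain such as octyl on this nitrogen would lower the number beyond that of compound 3, and whether a plain phenyl would behave as 2-methoxyphenyl does.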